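Methyl on the N-aryl ring of the spiro pyrazolone series

A few compounds are considered here, and "the series" means these few. Any claim that something is new, unique, unknown or untested is made for them only; others in the source may bear on it.

Measured so far:
compound 1 `CC1=NN(c2ccccc2)C(=O)[C@]12C(=O)C=CC[C@H]2c1ccc(C)cc1` — 2890 nM
compound 2 `CC1=NN(c2ccccc2)C(=O)[C@@]12C(=O)C=CC[C@H]2c1ccc(C)cc1` — 6090 nM
compound 3 `CC1=NN(c2ccccc2)C(=O)[C@@]12C(=O)C=CC[C@H]2c1ccccc1` — 3770 nM

All values come from a functional assay on A549 cells (Homo sapiens) for inhibition, read by MTT assay, with a stated time of 72 h; on this read-out higher numbers stand for weaker inhibition and lower numbers for stronger inhibition. Compound 1 gives 2890 nM in this assay, the lowest of the three numbers. Compounds 1 and 2 have the same atoms and bonds and differ only in configuration as drawn, and this assay shows a 2.1-fold higher number from compound 1 to compound 2 (0.32 log units; beyond the scatter); that the two differ only in the configuration as drawn the fact that compounds 1 and 2 differ only in the configuration as drawn is the sole thing that separates them. Compound 3 differs from compound 2 by methyl in place of hydrogen on an aromatic carbon, and this assay shows a 1.6-fold higher number from compound 3 to compound 2 (0.21 log units; within the scatter). How the cores of compound 1 and compound 3 differ is not broken down here; their values sit close to each other.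

Compound 4 `CC1=NN(c2ccc(C)cc2)C(=O)[C@]12C(=O)C=CC[C@H]2c1ccc(C)cc1` has not yet been measured. It differs from compound 1 by methyl in place of hydrogen on an aromatic carbon, the same change as that from compound 3 to compound 2, made here on the core of compound 1. Among the compounds with values here, on that change the one measured step, a 1.6-fold higher number from compound 3 to compound 2 (0.21 log units; within the scatter), was small, so a step of similar size is expected from compound 1 to compound 4, about a 1.4-fold higher number from compound 1 to compound 4 (0.14 log units; within the scatter), resting on compound 1 at 2890 nM and on the step from compound 3 to compound 2. Compound 4 is therefore expected to give about 4000 nM, most likely between 2000 nM and 9000 nM.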

Compound 4, half-maximal inhibitory concentration: 7520 nM
Beside the measured number, compound 4's estimate is 1.9-fold (0.27 log units) below it; the measured number falls inside the stated range.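

In this assay, methyl in place of hydrogen on an aromatic carbon gives a 2.6-fold higher number from compound 1 to compound 4 (0.42 log units; beyond the scatter); this step lies beyond the scatter and the earlier one within it, yet the two steps cannot be told apart: the same change on two cores in this assay, a 1.6-fold higher number (0.21 log units; within the scatter) from compound 3 to compound 2 and a 2.6-fold higher number (0.42 log units; beyond the scatter) from compound 1 to compound 4, 1.6-fold (0.21 log units) apart, within the scatter of two such steps

On these two cores, then, the readings give no sign that the core changes what this methyl does, and a step measured on one core was a fair guide to the step on the other. This does not show that the step is constant across the series, as it rests on only two steps and the cores compared are closely related: the fact that compounds 1 and 2 differ only in the configuration as drawn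

The compounds shown leave open whether the step keeps its size on a core that differs in more than configuration as drawn. They also leave open what other groups do in place of the hydrogen that methyl replaced in going from phenyl to 4-methylphenyl, such as a methoxy group, an amine or a carboxylic acid, when read in this assay.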